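Removing One Fluoro from Compound 3

The source may report more compounds than this note shows. Statements on the series, on what has been measured and on what is new or still open speak of the compounds shown alone.

Compound 1 `O=C(N/N=C/c1cccc(Br)c1)Nc1ccc(Oc2ccnc3[nH]ccc23)c(F)c1`: 4020 nM
Compound 2 `O=C(N/N=C/c1cccc(Cl)c1Cl)Nc1ccc(Oc2ccnc3[nH]ccc23)c(F)c1`: "not active" (no number reported)
Compound 3 `COc1ccc(/C=N/NC(=O)Nc2ccc(Oc3ccnc4[nH]ccc34)c(F)c2)cc1`: 6730 nM

Among the measured compounds shown here, all three compounds were tested in a functional assay on PC-3 cells (Homo sapiens) for antiproliferative activity, read by MTT assay, with a stated time of 72 h (on this read-out higher numbers stand for weaker inhibition and lower numbers for stronger inhibition), but compound 2 gave no number there, so only two numbers can be compared. For the measured compounds named here, compound 3 gives 6730 nM, and the one step that connects it to another number is a 1.7-fold higher number from compound 1 to compound 3 (0.22 log units; within the scatter). The two numbers therefore cannot be ranked.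

Compound 4 `COc1ccc(/C=N/NC(=O)Nc2ccc(Oc3ccnc4[nH]ccc34)cc2)cc1` has not yet been measured. Going by the values given here, its single structural change from compound 3 is hydrogen in place of fluoro on an aromatic carbon. The measured step offers only indirect guidance. The step of a 1.7-fold higher number from compound 1 to compound 3 (0.22 log units; within the scatter) concerns a different group, with 4-methoxyphenyl in place of 3-bromophenyl. Compounds 1, 2 and 3 all carry the fluoro, so no measurement here shows what losing it does. With no direct evidence, no step beyond the scatter is expected, although the uncertainty is wide. The expected step is a 1.0-fold lower number from compound 3 to compound 4 (0.02 log units; within the scatter). The estimated value for compound 4 is 6500 nM, with an expected range from 2500 nM to 17000 nM.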

Compound 4, half-maximal inhibitory concentration: "not active" (no number reported)
For compound 4 the study gives words and no number; no gap can be computed for the estimate.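

In this assay, among the compounds shown here, compound 4 is reported in words as not active, with no number, so no step from compound 3 to compound 4 can be read. No measurement shown explains this result. The compounds shown leave open how much replacing the fluoro with hydrogen changes the activity of compound 3 in numbers.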